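Swapping the amide tail for a sulfamoyl group

The source may hold more compounds than are shown below. What is called first, only, known or untested is meant among the compounds shown, and "the series" means these compounds.

Compound 1: `N#Cc1cccc(NC(=O)c2cn(Cc3c(F)cccc3F)c3ccc(=O)[nH]c3c2=O)c1` — 1070 nM
Compound 2: `O=C(NCc1ccncc1)c1ccc(NC(=O)c2cn(Cc3c(F)cccc3F)c3ccc(=O)[nH]c3c2=O)cc1` — 20 nM

Both values come from an in vitro assay on Sf21 cells for inhibition of high affinity 3',5'-cyclic-AMP phosphodiesterase 7A (Homo sapiens), read by scintillation proximity assay, with a stated time of 30 min; on this read-out higher numbers stand for weaker inhibition and lower numbers for stronger inhibition. Compound 2 stands lowest of the two, and compound 1 sits well above it, a gap beyond the usual scatter. Compound 3, `NS(=O)(=O)c1ccc(NC(=O)c2cn(Cc3c(F)cccc3F)c3ccc(=O)[nH]c3c2=O)cc1`, has not been measured. It differs from compound 2 in one place: sulfamoyl in place of ((pyridin-4-yl)methyl)carbamoyl on an aromatic carbon. Among the measured compounds shown here, no measured pair shows this exact exchange, so the step is uncertain. With the large tail of compound 2 gone, a move toward weaker inhibition is expected, of moderate size, a 7.5-fold higher number from compound 2 to compound 3 (0.88 log units; beyond the scatter). Compound 3 is therefore estimated at 150 nM, within a range of 30 nM to 800 nM in this assay.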

Compound 3, half-maximal inhibitory concentration: 34 nM
Compound 3: middle estimate off by 4.4-fold (0.64 log units), on the high side; low and high end bracket the measured number.
By their numbers in this assay, from the lowest: compounds 2 and 3 (each within the scatter of the next); then compound 1.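

Putting sulfamoyl in place of ((pyridin-4-yl)methyl)carbamoyl gives a 1.7-fold higher number from compound 2 to compound 3 (0.23 log units; within the scatter), so the pyridine ring and most of the larger group's atoms are not required for a number this low. The wider exchange of 3-cyanophenyl for 4-sulfamoylphenyl gives a 31-fold lower number from compound 1 to compound 3 (1.50 log units; beyond the scatter), a large step. No measurement offered here explains either result. Going by these compounds, that wider exchange alters both the group and its place on the ring, so their separate contributions remain unknown. On these data alone, whether a plain amine or a carboxylic acid could stand at this position is also open.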